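The source may report more compounds than this note shows. Statements on the series, on what has been measured and on what is new or still open speak of the compounds shown alone.

Measured compounds:
Compound 1 `Cc1ccc(-c2c3c(nc(C)c2[C@H](OC(C)(C)C)C(=O)O)CCN(CCCc2ccccc2)C3)cc1` gives > 40000 nM in an ADME assay on MT2 cells (Homo sapiens) for cytotoxicity, read by XTT assay, with a stated time of 4 days (a higher number here means that more compound is tolerated, a lower number that less compound is tolerated), a limit of the assay.
Compound 2 `Cc1nc2c(c(-c3cc(F)c4c(c3C)CCCO4)c1[C@H](OC(C)(C)C)C(=O)O)CN(CC1CC1c1ccccc1)CC2` gives > 40000 nM in this assay, again a limit.
Compound 3 `Cc1ccc(-c2c3c(nc(C)c2[C@H](OC(C)(C)C)C(=O)O)CCN(c2ccc(-c4ccccc4)cc2)C3)cc1` gives > 40000 nM in this assay, again a limit.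

Within the data shown here, compound 2 therefore stands at the same limit as the other two measured compounds: all three sit at the limit of > 40000 nM in this assay, at which 3 of the 3 values shown sit, and no compound among them gives a number. The unmeasured compound 4 `Cc1cccc(CCCN2CCc3nc(C)c([C@H](OC(C)(C)C)C(=O)O)c(-c4cc(F)c5c(c4C)CCCO5)c3C2)c1` arises from compound 2 by the change (2-(3-methylphenyl)ethyl in place of 2-phenylcyclopropyl on a saturated chain carbon bound to an amine nitrogen in a ring). Among the measured compounds shown here, the only measured single step, a step that the two limits leave unreadable from compound 1 to compound 3, is a change on the amine nitrogen in a ring rather than on the chain carbon bound to it, and its size cannot be read because both ends are limits. Nothing measured here points to a loss of tolerance for a change of this kind, so the expectation for compound 4 is that it also reaches the limit, with a step of a number no higher from compound 2 to compound 4 (the limit leaves the size open) that is expected to stay within the scatter. Compound 4 is estimated at 40000 nM in this assay, with a range from 20000 nM to 80000 nM.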

Compound 4, half-maximal cytotoxic concentration: > 40000 nM
Compound 4: a limit, no number (the forecaster's own chance of this, stated with the estimate: 85%); the middle value sits exactly at the limit.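

The results for compound 2 and compound 4 are both limits, not numbers, and the step between them cannot be read. The compounds shown leave open at what concentration any of them would harm the cells in this assay, as all stand at one limit: the limit of > 40000 nM in this assay, at which 4 of the 4 values shown sit.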